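Replacing the ring iodo substituent with an ester

A few compounds are considered here, and "the series" means these few. Any claim that something is new, unique, unknown or untested is made for them only; others in the source may bear on it.

Measured compounds:
- compound 1, `O=C(/C=C/c1ccc2c(c1)B(O)OC2)c1ccc(F)cc1`, 1400 nM
- compound 2, `O=C(/C=C/c1ccc2c(c1)B(O)OC2)c1ccc(I)cc1`, 4200 nM

The two measured compounds share one core and differ only in the group on the aromatic carbon of the outer ring. Within the data shown here, in a functional assay on SK-OV-3 cells (Homo sapiens) for cytotoxicity, read by MTT assay, with a stated time of 48 h (on this read-out lower numbers stand for stronger inhibition and higher numbers for weaker inhibition), compound 1 gives 1400 nM, and compound 2 gives 4200 nM, the highest of the two numbers; the single step between them, a 3.0-fold higher number from compound 1 to compound 2 (0.48 log units; beyond the scatter), is modest but clears the scatter.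

Compound 3, `CCOC(=O)c1ccc(C(=O)/C=C/c2ccc3c(c2)B(O)OC3)cc1`, has not yet been measured in this assay. It differs from compound 2 as follows: ethoxycarbonyl in place of iodo on an aromatic carbon. Among the measured compounds shown here, only one measured step concerns this position, and it shows that swapping the group there moved the number by a modest amount in this assay. The incoming ethoxycarbonyl group, however, is unlike either group already tried, so its direction cannot be read from that step. A change of similar size, in either direction, is therefore expected, with the step of a 1.4-fold lower number from compound 2 to compound 3 (0.15 log units; within the scatter) not clearly beyond the scatter. Compound 3 is estimated at 3000 nM, within 1000 nM to 9000 nM.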

Compound 3, half-maximal inhibitory concentration: 7100 nM
Estimate against measurement, compound 3: 2.4-fold (0.37 log units) below, within the range that was stated.
By their numbers in this assay, from the lowest: compound 1; then compounds 2 and 3 (each within the scatter of the next).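

Putting ethoxycarbonyl in place of iodo adds heavy atoms and two hydrogen-bond acceptors, yet in this assay it gives a 1.7-fold higher number from compound 2 to compound 3 (0.23 log units; within the scatter) and so cannot be told apart from iodo at this position. Measured against fluoro, the same group gives a 5.1-fold higher number from compound 1 to compound 3 (0.71 log units; beyond the scatter), which leaves compound 1 with the lowest number of the three, clearly separated from both compound 2 and compound 3. The series therefore splits into fluoro on one side and iodo and ethoxycarbonyl together on the other, although the data available give no explanation for that split.

Among these compounds, with only three groups at this position, it remains open whether the gap from compound 1 reflects something particular to fluoro or would also appear with other groups. A carboxylic acid or an amide on this aromatic carbon would help show whether the ethyl part of the ester matters, while an amine or a chloro group would test how far the fluoro result extends.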